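Swapping a Sulfonamide for an Ester: Expected Cell Tolerance

The source may report more compounds than this note shows. Statements on the series, on what has been measured and on what is new or still open speak of the compounds shown alone.

Measured compounds:
Compound 1 `CCOC(=O)c1cnc(N2CCN(Cc3ccc(Br)cc3)CC2)nc1Oc1c(C)cc(-c2ccc(C#N)cc2)cc1C` — > 125000 nM
Compound 2 `CCOC(=O)c1cnc(N2CCN(Cc3ccc(S(N)(=O)=O)cc3)CC2)nc1Oc1c(C)cc(-c2ccc(C#N)cc2)cc1C` — >= 7930 nM

In an ADME assay on MT4 cells (Homo sapiens) for cytotoxicity, read by MTT assay, with a stated time of 4 days (a higher number here means that more compound is tolerated, a lower number that less compound is tolerated), compound 1 reaches only a limit of the assay, > 125000 nM. Compound 2 likewise yields only a limit in this assay, >= 7930 nM, so its true position is not pinned down. Within the data shown here, the single change between them, a step that the two limits leave unreadable from compound 1 to compound 2, is consequently of unreadable size; both values sit at limits, as the limit of > 125000 nM in this assay, at which 1 of the 2 values shown sits, and the limit of >= 7930 nM in this assay, at which 1 of the 2 values shown sits, show.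

Compound 3 `CCOC(=O)c1ccc(CN2CCN(c3ncc(C(=O)OCC)c(Oc4c(C)cc(-c5ccc(C#N)cc5)cc4C)n3)CC2)cc1` differs from compound 2 by ethoxycarbonyl in place of sulfamoyl on an aromatic carbon. Among the measured compounds shown here, no measured step involves this particular exchange, and the only step recorded is unreadable, so there is no basis for expecting a shift in either direction beyond the scatter. Compound 3 is therefore estimated at 30000 nM, within a range from 7000 nM to 125000 nM. The step this estimate means, a step that the limit leaves unreadable from compound 2 to compound 3, is expected to be small.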

Compound 3, half-maximal cytotoxic concentration: > 125000 nM
Compound 3: no number, only a limit; the forecaster's own chance of this, stated with the estimate: 60%; at least 4.1-fold (0.61 log units) between middle value and limit.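

Compound 3 reaches only a limit of the assay, > 125000 nM. Among these compounds, all three values are limits, so no step among compound 1, compound 2 and compound 3 can be read in this assay. The compounds shown leave open the true half-maximal cytotoxic concentration of each, and whether bromo, sulfamoyl and ethoxycarbonyl differ at all here.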